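Replacing Formyl with Chloromethyl: What to Expect

This account rests on a few compounds, and the source may have more. Where it says the series, first, only, none or still open, it means among the compounds named here.

For the measured compounds named here, in a functional assay on MCF7 cells (Homo sapiens) for antiproliferative activity, read by MTT assay, with a stated time of 48 h (a lower number here means a stronger inhibitor, a higher number a weaker inhibitor), compound 2 `CC(C)=CCC[C@]1(C)/C=C/[C@@H](OC(=O)C=C(C)C)[C@](C)(O)/C=C/C(=O)/C(C=O)=C\C1` gives 12600 nM, the higher of the two numbers so far, which makes it the weaker inhibitor of the pair. Compound 1 `CC(=O)OC/C1=C/C[C@](C)(CCC=C(C)C)/C=C/[C@@H](OC(=O)C=C(C)C)[C@](C)(O)/C=C/C1=O` gives 4510 nM. Going by the values given here, the only measured step, a 2.8-fold higher number from compound 1 to compound 2 (0.45 log units; beyond the scatter), is modest and comes from formyl taking the place of acetoxymethyl on a double-bonded ring carbon.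

Compound 3 `CC(C)=CCC[C@]1(C)/C=C/[C@@H](OC(=O)C=C(C)C)[C@](C)(O)/C=C/C(=O)/C(CCl)=C\C1` changes that same carbon, with chloromethyl in place of formyl on a double-bonded ring carbon. Compound 3 thus loses the formyl and, like compound 1, carries a substituted methyl group there instead. This suggests a partial return towards the level of compound 1 at 4510 nM, though a single step is thin evidence. A modest drop is expected, estimated as a 2.1-fold lower number from compound 2 to compound 3 (0.32 log units; beyond the scatter). The expected value for compound 3 is 6000 nM, within a range of 2200 nM to 16000 nM.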

Compound 3, half-maximal inhibitory concentration: 610 nM
Compound 3: middle estimate off by 9.8-fold (0.99 log units), on the high side, and the stated range ends above it.
By their numbers in this assay, from the lowest: compound 3; then compound 1; then compound 2.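

Swapping formyl for chloromethyl on this double-bonded ring carbon gives a 21-fold lower number from compound 2 to compound 3 (1.32 log units; beyond the scatter) in this assay, so the group here can shift the number much further than the earlier step suggested. The change also carries compound 3 past compound 1 rather than merely back to its level, with a 7.4-fold lower number from compound 1 to compound 3 (0.87 log units; beyond the scatter) when chloro takes the place of acetoxy on the saturated chain carbon, so having a substituted methyl group on this ring carbon does not by itself set the number. Nothing available here explains why chloromethyl stands apart.

As far as these compounds go, whether chlorine itself is needed remains open, a question that bromomethyl, hydroxymethyl or a plain methyl group on this carbon could answer. From the compounds shown here alone, it is also open whether the gain would persist with a different group in place of the ((2-methylprop-1-en-1-yl)carbonyl)oxy group.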